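Dichloro lactam series: replacing the isoxazole with a hydroxymethyl oxolane

This account rests on a few compounds, and the source may have more. Where it says the series, first, only, none or still open, it means among the compounds named here.

Compound 2 `Cc1cc(C)c(CN2CCc3c(Cl)cc(-c4c(C)noc4C)c(Cl)c3C2=O)c(=O)[nH]1` is the reference point here. Going by the values given here, in an assay on cells for inhibition of histone-lysine N-methyltransferase EZH2 (Homo sapiens), read by ELISA, with a stated time of 72 h (a lower number here means a stronger inhibitor, a higher number a weaker inhibitor), compound 2 gives 17 nM, the only number recorded for it; a further entry for compound 2 carries no single value. Compound 1 `COC(c1cc(Cl)c2c(c1Cl)C(=O)N(Cc1c(C)cc(C)[nH]c1=O)CC2)C1CCOCC1` shares the core and is the other measured member; in this assay compound 1 gives 1460 nM; 9 nM (2 entries), two entries that sit far apart, as the record the several entries of compound 1 in this assay, 1460 nM; 9 nM (2 entries) shows, so the spread for compound 1 is large. Compound 3 `Cc1cc(C)c(CN2CCc3c(Cl)cc([C@H](CO)[C@H]4CCCO4)c(Cl)c3C2=O)c(=O)[nH]1` differs from compound 2 at one place only: a group of 8 heavy atoms (6 carbon, 2 oxygen; one five-membered non-aromatic ring with 1 hetero atom) in place of a group of 7 heavy atoms (5 carbon, 1 nitrogen, 1 oxygen; one five-membered aromatic ring with 2 hetero atoms), on an aromatic carbon. Among the compounds with values here, no measured pair in this set traces that exchange, so its size cannot be read from the data. Given the scatter, the step from compound 2 to compound 3 is expected to be modest, a 1.5-fold higher number from compound 2 to compound 3 (0.17 log units; within the scatter), most likely a small loss. Compound 3 is therefore estimated at 25 nM in this assay, with a range from 8 nM to 80 nM.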

Compound 3, half-maximal inhibitory concentration: 40 nM
Compound 3: middle estimate off by 1.6-fold (0.20 log units), on the low side, and the stated range covers the measured number.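

In this assay, going by these compounds alone, the exchange of 3,5-dimethyl-1,2-oxazol-4-yl for the hydroxymethyl oxolane group gives the first measured step at this aromatic carbon, a 2.4-fold higher number from compound 2 to compound 3 (0.37 log units; beyond the scatter), a modest loss beyond the scatter. The five-membered aromatic ring at this carbon can therefore give way to a non-aromatic ring with 2 defined stereocentres and 1 hydrogen-bond donor, and compound 3 still gives 40 nM in this assay. Compound 1 offers no firm second reference for a non-aromatic group at this carbon because its entries sit far apart: the several entries of compound 1 in this assay, 1460 nM; 9 nM (2 entries).

The compounds shown leave open how much of the step belongs to the hydroxymethyl arm and how much to the oxolane ring, and how the other stereoisomers of compound 3 compare. Also open, from the compounds shown here alone, is whether an amine or a carboxylic acid in place of the hydroxyl would keep the value of compound 3.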